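A few compounds are considered here, and "the series" means these few. Any claim that something is new, unique, unknown or untested is made for them only; others in the source may bear on it.

Of the compounds shown here, three have been measured in an assay on CHO-K1 cells for displacement of a labelled ligand from Neuronal acetylcholine receptor; alpha4/beta2 (Homo sapiens), read by scintillation counting; a lower number here means a stronger inhibitor, a higher number a weaker inhibitor. Compound 1, with the structure `Brc1ccc(OC[C@@H]2C[C@H]3C[C@H]3N2)cn1`, gives 46.5 nM in this assay. Compound 2, `c1ccc2ncc(OC[C@@H]3C[C@H]4C[C@H]4N3)cc2c1`, gives 600 nM, and compound 3, `Clc1ccc(OC[C@]23C[C@H]2CCN3)cn1`, gives 341 nM. Compound 1 thus has the lowest of the three numbers, and the gaps from compound 1 to the other two are wider than the ordinary scatter of repeated measurements, so on these numbers compound 1 binds most tightly.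

The next compound, compound 4, is `FC(F)(F)c1ccc(OC[C@@H]2C[C@H]3C[C@H]3N2)cn1`. It differs from compound 1 in one place only: trifluoromethyl in place of bromo on an aromatic carbon. The group that leaves and the group that enters are both without ring, without hydrogen-bond donors or acceptors and without net charge, and both sit on the aromatic carbon next to the ring nitrogen, para to a group of 8 heavy atoms.

Within the data shown here, no step between two measured compounds that differ in only one place is available, so the size of this step can only be expected, not read off. The expectation is that the change from compound 1 to compound 4 costs some affinity, a step of a 3.2-fold higher number from compound 1 to compound 4 (0.51 log units; beyond the scatter) in this assay. For compound 4 the estimated value in this assay is 150 nM, expected to fall between 50 nM and 500 nM.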

Compound 4, inhibition constant: 768 nM
Compound 4: the middle estimate sits 5.1-fold (0.71 log units) below what was measured; measured number outside the range, above it.
By their numbers in this assay, from the lowest: compound 1; then compounds 3, 2 and 4 (each within the scatter of the next, the first and the last beyond it).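

Among these compounds, this is the first step between two measured compounds that differ in one place, and it shows that the aromatic carbon next to the ring nitrogen is far from indifferent to what it carries: trifluoromethyl in place of bromo gives a 17-fold higher number from compound 1 to compound 4 (1.22 log units; beyond the scatter) in this assay on the same core. The step is large even though the two groups share several counted features, with no ring, no hydrogen-bond donors or acceptors and no net charge in either; among the features counted here they differ in size, 1 heavy atom against 4. Nothing measured here explains why affinity falls with this change.

With a single step at this position, the compounds shown cannot tell whether bromo is especially well suited to this carbon or trifluoromethyl especially poorly suited to it. As far as these compounds go, a methyl or a nitrile group on the same carbon of the core of compound 1 would give further steps from the same starting point, and whether this swap costs as much on another core also remains open.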